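Extending the chain of compound 3

The source may hold more compounds than are shown below. What is called first, only, known or untested is meant among the compounds shown, and "the series" means these compounds.

Values in a functional assay on MCF7 cells (Homo sapiens) for cytotoxicity (a lower number here means a stronger inhibitor, a higher number a weaker inhibitor), are:
- Compound 1 `C#C[C@H](O)/C=C/CCCCCCCCC/C=C\CCCCCCCCC/C=C/[C@@H](O)C#C` gives 160 nM
- Compound 2 `C#C[C@H](O)/C=C/CCCCCCCCC/C=C\CCCCCCCCCCC/C=C/[C@@H](O)C#C` gives 160 nM
- Compound 3 `C#C[C@H](O)/C=C/CCCCC/C=C\CCCC/C=C\CCCCCCCCC/C=C/[C@@H](O)C#C` gives 160 nM

Compound 3 stands level with the other two, with no gap among the three at 160 nM on these numbers. Compound 4 `C#C[C@H](O)/C=C/CCCCCCC/C=C\CCCC/C=C\CCCCCCCCC/C=C/[C@@H](O)C#C` differs from compound 3 by a single swap, a group of 8 heavy atoms (7 carbon, 1 oxygen; no ring) in place of a group of 6 heavy atoms (5 carbon, 1 oxygen; no ring), on a saturated chain carbon, five bonds along the chain from a double-bonded chain carbon and nothing else. Among the measured compounds shown here, the only measured step of this kind is no change at the digits printed from compound 1 to compound 2 (within the scatter) and it lies within the scatter. That swap sat nine bonds along the chain from a double-bonded chain carbon, not five, so it is only a near guide. The estimated step is no change at the digits printed from compound 3 to compound 4 (within the scatter) and is expected to stay within the scatter in this assay as well. For compound 4 the expected value is 160 nM with an estimated range from 70 nM to 350 nM and one precedent is thin support.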

Compound 4, half-maximal inhibitory concentration: 160 nM
Estimate against measurement, compound 4: no gap at the digits printed; the range from low to high includes it.
By their numbers in this assay, from the lowest: compounds 1, 2, 3 and 4 (each within the scatter of the next).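

In this assay, placing the group of 8 heavy atoms (7 carbon, 1 oxygen; no ring) on a saturated chain carbon, five bonds along the chain from a double-bonded chain carbon, gives no change at the digits printed from compound 3 to compound 4 (within the scatter). The earlier step showed this only at the place nine bonds along the chain. The same change has now been seen at two places, with the same outcome: the same change on two cores in this assay, no change at the digits printed (within the scatter) from compound 1 to compound 2 and no change at the digits printed (within the scatter) from compound 3 to compound 4, 1.0-fold (0.00 log units) apart, within the scatter of two such steps

Going by these compounds, what an amine or a carboxylic acid on this chain would do in this assay stays open. So does the effect of a much longer chain.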